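Fluorine shift on the benzylidene ring of compound 2

The compounds below may be only part of what the source reports. "The series", "measured", "known", "first", "only" and "open" are said of these compounds alone.

Compound 1 `O=C1/C(=C/c2ccccc2F)CCc2cc(O)ccc21`: 1740 nM
Compound 2 `O=C1/C(=C/c2ccccc2)CCc2ccc(O)cc21`: 710 nM
Compound 3 `O=C1/C(=C/c2ccccc2F)CCc2ccc(O)cc21`: 1350 nM

Of the compounds shown here, three have been measured in a functional assay on RAW264.7 cells (Mus musculus) for inhibition; a lower number here means a stronger inhibitor, a higher number a weaker inhibitor. Compound 2 gives the lowest number of the three; compound 3 comes nearest, and compound 1 lies furthest away, a gap that reaches beyond the scatter. Compound 4 `O=C1/C(=C/c2cccc(F)c2)CCc2ccc(O)cc21` has not yet been measured. It differs from compound 2 by fluoro in place of hydrogen on an aromatic carbon. Among the compounds with values here, the only measured step of the same kind is a 1.9-fold higher number from compound 2 to compound 3 (0.28 log units; within the scatter), which placed the fluoro on a different aromatic carbon of the same ring. That step was small, so the fluoro on this ring has so far made no difference beyond the scatter. On that basis the number for compound 4 is expected to stay close to that of compound 2, with at most a mild rise, giving an estimated step of a 1.3-fold higher number from compound 2 to compound 4 (0.10 log units; within the scatter). Compound 4 is therefore estimated at 900 nM, with a likely range of 400 nM to 2000 nM.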

Compound 4, half-maximal inhibitory concentration: 830 nM
Estimate against measurement, compound 4: 1.1-fold (0.04 log units) above; the range from low to high includes it.
By their numbers in this assay, from the lowest: compounds 2, 4, 3 and 1 (each within the scatter of the next, the first and the last beyond it).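

Moving to a carbon meta to a large group on the six-membered aromatic ring of carbon only, fluoro in place of hydrogen gives in this assay a 1.2-fold higher number from compound 2 to compound 4 (0.07 log units; within the scatter) and so again stays close to compound 2. Taken with a 1.9-fold higher number from compound 2 to compound 3 (0.28 log units; within the scatter) on a different carbon of that ring, this shows that two placements of the fluoro each leave the number within the scatter, so a single fluoro at this position, unlike at the earlier one alone, is no longer an isolated case. Nothing available explains this small effect.

The compounds shown leave open whether a larger or different group at this place, such as methoxy, trifluoromethyl, an amine or a carboxylic acid, would move the number beyond the scatter. They also leave open how fluoro behaves on the remaining carbons of this ring.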